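Sulfonyl Aryl Substituents in an Integrin Antagonist Series

A few compounds are considered here, and "the series" means these few. Any claim that something is new, unique, unknown or untested is made for them only; others in the source may bear on it.

The series shares one core, and varies only the aryl group on the sulfonyl sulfur. Compound 1 `O=C(NC[C@@H](C(=O)O)S(=O)(=O)c1c(Cl)cccc1Cl)C1=NOC2(CCC(CNc3ncc[nH]3)CC2)C1` carries a 2,6-dichlorophenyl there; in a functional assay for antagonist activity at integrin alpha-5/beta-1 (Homo sapiens), read by ELISA (on this read-out lower numbers stand for stronger inhibition and higher numbers for weaker inhibition), compound 1 gives 3000 nM. Compound 2 `O=C(NC[C@@H](C(=O)O)S(=O)(=O)c1ccccc1)C1=NOC2(CCC(CNc3ncc[nH]3)CC2)C1` carries an unsubstituted phenyl; in this assay compound 2 gives 4700 nM. Within the data shown here, of the two numbers measured so far, compound 2 has the higher one, but the step of a 1.6-fold higher number from compound 1 to compound 2 (0.19 log units; within the scatter) is within the scatter, so the two compounds are not separated by these data.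

Compound 3 `Cc1cccc(C)c1S(=O)(=O)[C@@H](CNC(=O)C1=NOC2(CCC(CNc3ncc[nH]3)CC2)C1)C(=O)O` is the next member. Its change from compound 2 is 2,6-dimethylphenyl in place of phenyl on a sulfonyl sulfur. Among the measured compounds shown here, the only measured step that bears on it is the one from compound 1 to compound 2, where removing two substituents flanking the sulfonyl attachment shifted the number by a 1.6-fold higher number from compound 1 to compound 2 (0.19 log units; within the scatter). Reintroducing two substituents at those same positions, now methyl in place of chlorine, is therefore expected to move the number by a 1.3-fold lower number from compound 2 to compound 3 (0.13 log units; within the scatter) at most, a shift that stays within the scatter. For compound 3 the estimate in this assay is 3500 nM, with a range from 1500 nM to 8000 nM.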

Compound 3, half-maximal inhibitory concentration: 1800 nM
Compound 3: the middle estimate sits 1.9-fold (0.29 log units) above what was measured; the measured number falls inside the stated range.
By their numbers in this assay, from the lowest: compounds 3, 1 and 2 (each within the scatter of the next, the first and the last beyond it).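

In this assay the step of a 2.6-fold lower number from compound 2 to compound 3 (0.42 log units; beyond the scatter) is the first change on the sulfonyl sulfur shown to lie beyond the scatter, so this position does respond to the aryl group, if modestly. The step of a 1.7-fold lower number from compound 1 to compound 3 (0.22 log units; within the scatter) lies within the scatter, so 2,6-dimethylphenyl and 2,6-dichlorophenyl are not separated by these data, and carrying two substituents is not enough on its own to set a compound apart from compound 2: compound 3 stands apart from it, while compound 1, which goes against any such pattern, does not. No measurement of any property of these aryl groups accompanies the result, so the step can be stated only as a difference in numbers.

Still open, going by these compounds, is whether a single methyl on the phenyl gives part of the step seen with 2,6-dimethylphenyl, and whether methoxy, ethyl or an amine in place of the methyl groups would hold, extend or lose it. Also open, on these data alone, is whether the sulfonyl sulfur needs an aryl group at all, or whether a saturated ring such as cyclohexyl or a plain butyl chain would serve there.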